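This account rests on a few compounds, and the source may have more. Where it says the series, first, only, none or still open, it means among the compounds named here.

Of the compounds shown here, three on a shared core have been measured in a functional assay for agonist activity at Glucose-dependent insulinotropic receptor (Homo sapiens); on this read-out higher numbers stand for an effect only at larger amounts of compound and lower numbers for an effect already at smaller amounts. Compound 1 `CCCc1noc(C2CCN(c3ncnc(Nc4ccc(S(C)(=O)=O)cc4)c3[N+](=O)[O-])CC2)n1` gives 430 nM. Going by the values given here, compound 2 `CC(C)(C)c1noc(C2CCN(c3ncnc(Nc4ccc(S(C)(=O)=O)cc4)c3[N+](=O)[O-])CC2)n1` gives 1.5 nM, and the step of a 290-fold lower number from compound 1 to compound 2 (2.46 log units; beyond the scatter) is the only single change measured so far. Compound 3 `CCCS(=O)(=O)c1ccc(Nc2ncnc(N3CCC(c4nc(C(C)C)no4)CC3)c2[N+](=O)[O-])cc1` gives 4.7 nM, which places it second highest of the three numbers: its nearest neighbour is compound 2, with a number beyond the scatter below it, and compound 1 stands furthest away, well above it.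

Compound 4 `CCS(=O)(=O)c1ccc(Nc2ncnc(N3CCC(c4nc(C(C)C)no4)CC3)c2[N+](=O)[O-])c(F)c1` is not yet measured. It differs from compound 3 in one place: a group of 12 heavy atoms (8 carbon, 2 oxygen, 1 fluorine, 1 sulfur; one six-membered aromatic ring of carbon only) in place of a group of 12 heavy atoms (9 carbon, 2 oxygen, 1 sulfur; one six-membered aromatic ring of carbon only), on a nitrogen on an aromatic ring. The group that leaves is 4-(propylsulfonyl)phenyl; the group that enters has no common name. Among the compounds with values here, no measured step touches this part of the molecule: the one step known concerns a substituent on an aromatic carbon elsewhere in the core, and it was large. Nothing measured therefore speaks for a large move in this assay, and a small change, in either direction, is the expectation. The estimate for compound 4 in this assay is 5 nM, with a range from 1.5 nM to 16 nM. The step this estimate means, a 1.1-fold higher number from compound 3 to compound 4 (0.03 log units; within the scatter), is expected to lie within the scatter.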

Compound 4, half-maximal effective concentration: 7 nM
Compound 4: middle estimate off by 1.4-fold (0.15 log units), on the low side; measured number inside the range.
By their numbers in this assay, from the lowest: compound 2; then compounds 3 and 4 (each within the scatter of the next); then compound 1.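

In this assay, going by these compounds alone, the exchange at the group on a nitrogen on an aromatic ring gives a 1.5-fold higher number from compound 3 to compound 4 (0.17 log units; within the scatter), so this is the first measured change at this part of the molecule, and it leaves the number within the scatter. The 4-(propylsulfonyl)phenyl group, with 9 carbon atoms, gives way to a group with 8 carbon atoms and 1 fluorine atom, and the two compounds cannot be told apart on this read-out; at this position, this exchange is thus far quieter than the large step seen elsewhere on the core between propyl and tert-butyl. No measurement is available that would explain the result.

The exchange alters the sulfonyl chain and adds fluorine in one move, so the compounds shown do not separate the contribution of either change, and they could conceal opposing contributions. They also leave open whether this position stays as quiet with a very different group in place of the sulfonyl, such as an amine or a carboxylic acid, and whether the same holds with tert-butyl on the core.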